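From cyclopropylsulfonyl to (1-methylcyclopropyl)sulfonyl

The compounds below may be only part of what the source reports. "The series", "measured", "known", "first", "only" and "open" are said of these compounds alone.

In an ADME assay for permeability, using PAMPA (on this read-out higher numbers stand for higher permeability and lower numbers for lower permeability), compound 1 (`Cc1cc(C(=O)N[C@H]2CCCCC/C=C\[C@@H]3C[C@@]3(C(=O)NS(=O)(=O)C3CC3)NC(=O)[C@@H]3C[C@@H](Oc4nc5ccccc5nc4C)CN3C2=O)no1`) gives 3.5 10^-6 cm/s and compound 2 (`Cc1cc(C(=O)N[C@H]2CCCCC/C=C\[C@@H]3C[C@@]3(C(=O)NS(=O)(=O)C3CC3)NC(=O)[C@@H]3C[C@@H](Oc4nc5cc(F)ccc5nc4C(F)(F)F)CN3C2=O)no1`) gives 5.1 10^-6 cm/s. Among the compounds with values here, these two values lie within the usual scatter of each other, so compound 2 stands level with compound 1 on the numbers so far. Compound 3 (`Cc1cc(C(=O)N[C@H]2CCCCC/C=C\[C@@H]3C[C@@]3(C(=O)NS(=O)(=O)C3(C)CC3)NC(=O)[C@@H]3C[C@@H](Oc4nc5cc(F)ccc5nc4C(F)(F)F)CN3C2=O)no1`) departs from compound 2 at one place: methyl in place of hydrogen on a saturated ring carbon. This puts methyl in place of hydrogen on a saturated ring carbon, turning cyclopropylsulfonyl into (1-methylcyclopropyl)sulfonyl. Within the data shown here, no measured pair yet shows a change at this place, so the expectation rests on the small size of the structural change alone. In this assay, the expected step is a 1.1-fold higher number from compound 2 to compound 3 (0.03 log units; within the scatter), with no shift beyond the scatter anticipated in either direction. For compound 3 the estimated value is 5.5 10^-6 cm/s, with an expected range from 2.8 10^-6 cm/s to 10 10^-6 cm/s.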

Compound 3, apparent permeability: 12.1 10^-6 cm/s
Compound 3: the middle estimate sits 2.2-fold (0.34 log units) below what was measured, and the stated range ends below it.
By their numbers in this assay, from the lowest: compounds 1 and 2 (each within the scatter of the next); then compound 3.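

In this assay, methyl in place of hydrogen on a saturated ring carbon gives a 2.4-fold higher number from compound 2 to compound 3 (0.38 log units; beyond the scatter). This is the first change shown at this position, and it shows that turning cyclopropylsulfonyl into (1-methylcyclopropyl)sulfonyl, a difference of a single carbon, can move the read-out beyond the scatter. Nothing measured here accounts for the step, which remains a single pair on a single core.

The compounds shown leave open whether ethyl, a fluorine atom or an amine on that same ring carbon would extend the step, lose it or reverse it. They also leave open whether the same change from cyclopropylsulfonyl to (1-methylcyclopropyl)sulfonyl would give a comparable step on the core of compound 1.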